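Adding a methoxy group to compound 3

This account rests on a few compounds, and the source may have more. Where it says the series, first, only, none or still open, it means among the compounds named here.

compound 1 `CCCn1c(-c2ccc(C)cc2C)cs/c1=N\C(=O)c1ccccc1` gives 292 nM
compound 2 `CCn1c(-c2ccccc2)cs/c1=N\C(=O)c1ccccc1` gives 51.5 nM
compound 3 `COc1cc(-c2cs/c(=N\C(=O)c3ccccc3)n2C)cc(OC)c1OC` gives 1070 nM

In a functional assay on MDA-MB-231 cells (Homo sapiens), read by microscopy and transwell migration, with a stated time of 24 h (a lower number here means a stronger inhibitor, a higher number a weaker inhibitor), compound 3 stands highest of the three at 1070 nM and is the weakest inhibitor here, clear of the scatter from both others. Compound 1 and compound 2 differ from it in more than one place, so their gaps cannot be tied to any single group.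

Compound 4 `COc1ccc(C(=O)/N=c2\scc(-c3cc(OC)c(OC)c(OC)c3)n2C)cc1` changes compound 3 in one place, with methoxy in place of hydrogen on an aromatic carbon, para to a large group (methoxy in place of hydrogen on an aromatic carbon). Phenyl thus becomes 4-methoxyphenyl.

Among the measured compounds shown here, no measured pair shows what a change of this kind does in this assay so no direction can be argued with confidence. The expectation therefore starts from compound 3 at 1070 nM and stays close to it, with no step beyond the scatter. The estimated change is small, a 1.2-fold lower number from compound 3 to compound 4 (0.08 log units; within the scatter) and the uncertainty around it is wide. For compound 4 the expected value is an estimated 900 nM (range 300 nM to 2700 nM).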

Compound 4, half-maximal inhibitory concentration: 8040 nM
The estimate for compound 4 lay 8.9-fold (0.95 log units) below the measured number, and the stated range ends below it.
By their numbers in this assay, from the lowest: compound 2; then compound 1; then compound 3; then compound 4.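

In this assay, the swap of phenyl for 4-methoxyphenyl gives a 7.5-fold higher number from compound 3 to compound 4 (0.88 log units; beyond the scatter), so the aromatic carbon para to a large group is not indifferent to what it carries: methoxy in place of hydrogen weakens inhibition beyond the scatter. The earlier compounds shown here could not show this, as they differ from one another in more than one place. Nothing measured here accounts for the loss.

As far as these compounds go, whether other groups on this same carbon, such as a hydroxyl, a fluorine or an amine, would weaken inhibition as well remains open, so this single step cannot separate an effect of methoxy itself from one of any replacement for hydrogen. Also open, from the compounds shown here alone, is whether methoxy at this place would produce a similar step on the other substitution patterns, such as that of compound 2.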